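Swapping a tert-butyl ester for a methoxyethyl ester

A few compounds are considered here, and "the series" means these few. Any claim that something is new, unique, unknown or untested is made for them only; others in the source may bear on it.

Of the compounds shown here, two sharing one core have been measured. Compound 1 `COCCOC(=O)C1=C(C)NC(C)=C(C(=O)OCCOC)C1c1cnc(SC)n1Nc1ccccc1` gives 17.9 nM in an assay on isolated protein (strain albino) for antagonist activity at Voltage-dependent L-type calcium channel subunit alpha-1C (Cavia porcellus) (on this read-out higher numbers stand for weaker inhibition and lower numbers for stronger inhibition), while compound 2 `CSc1ncc(C2C(C(=O)OC(C)C)=C(C)NC(C)=C2C(=O)OC(C)(C)C)n1Nc1ccccc1` gives 68.2 nM, the higher of the two numbers and beyond the scatter from compound 1. Compound 3 `COCCOC(=O)C1=C(C)NC(C)=C(C(=O)OC(C)C)C1c1cnc(SC)n1Nc1ccccc1` differs from compound 2 by 2-methoxyethyl in place of tert-butyl on an oxygen next to a carbonyl group. Among the measured compounds shown here, with no measured step for this change, compound 3 is expected to move modestly toward compound 1, a step of a 1.9-fold lower number from compound 2 to compound 3 (0.29 log units; within the scatter). The estimate for compound 3 is 35 nM, between 15 nM and 80 nM.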

Compound 3, half-maximal inhibitory concentration: 53.4 nM
Estimate against measurement, compound 3: 1.5-fold (0.18 log units) below; the range from low to high includes it.
By their numbers in this assay, from the lowest: compound 1; then compounds 3 and 2 (each within the scatter of the next).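

In this assay, 2-methoxyethyl in place of tert-butyl on an oxygen next to a carbonyl group gives a 1.3-fold lower number from compound 2 to compound 3 (0.11 log units; within the scatter), so with isopropyl on the second ester this change does not separate from the scatter. Isopropyl in place of 2-methoxyethyl gives a 3.0-fold higher number from compound 1 to compound 3 (0.47 log units; beyond the scatter), the only step here that lies beyond the scatter. Nothing available explains either step.

Going by these compounds, it stays open how a 2-(dimethylamino)ethyl group on this oxygen would read, and whether the tert-butyl change would read the same with 2-methoxyethyl on the second ester.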